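Fluoro in Place of Hydrogen: From Compound 2 to Compound 4

This account rests on a few compounds, and the source may have more. Where it says the series, first, only, none or still open, it means among the compounds named here.

Compound 2 `CC(c1ccc(-c2ccccc2)c(F)c1)c1nnc2n1N=C(c1ccccc1)CS2` stands second highest of the three numbers in a functional assay on Huh-7 cells (Homo sapiens) for inhibition, read by sulforhodamine B assay, with a stated time of 72 h (on this read-out higher numbers stand for weaker inhibition and lower numbers for stronger inhibition), giving 6700 nM. Its nearest neighbour is compound 3 `CC(C)Cc1ccc(C(C)c2nnc3n2N=C(c2ccc(Cl)cc2)CS3)cc1`, which gives 5700 nM; the furthest is compound 1 `CC(c1ccc(-c2ccccc2)c(F)c1)c1nnc2n1N=C(c1ccc(OC(F)(F)F)cc1)CS2`, which gives 8400 nM. Both gaps lie within the scatter. Compound 4 `CC(c1ccc(-c2ccccc2)c(F)c1)c1nnc2n1N=C(c1ccc(F)cc1)CS2` differs from compound 2 by fluoro in place of hydrogen on an aromatic carbon, on an aromatic carbon of a six-membered aromatic ring of carbon only, para to a large group. Among the measured compounds shown here, only one measured step bears on this ring, a 1.3-fold lower number from compound 1 to compound 2 (0.10 log units; within the scatter), and it stayed within the scatter. The expected step is therefore a 1.1-fold lower number from compound 2 to compound 4 (0.05 log units; within the scatter), nothing beyond the scatter. Compound 4 is accordingly estimated at 6000 nM, with a range from 3000 nM to 12000 nM.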

Compound 4, half-maximal inhibitory concentration: 4900 nM
Compound 4: the middle estimate sits 1.2-fold (0.09 log units) above what was measured; the range from low to high includes it.
By their numbers in this assay, from the lowest: compounds 4, 3, 2 and 1 (each within the scatter of the next).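

Fluoro in place of hydrogen gives a 1.4-fold lower number from compound 2 to compound 4 (0.14 log units; within the scatter), and fluoro in place of trifluoromethoxy gives a 1.7-fold lower number from compound 1 to compound 4 (0.23 log units; within the scatter). Hydrogen, fluoro and trifluoromethoxy at this position thus all lie within the scatter of one another, so this small set of groups shows no step beyond it. Nothing measured here speaks to why the steps have this size. From the compounds shown here alone, whether an amine, a carboxylic acid or a longer chain at this position would move the number beyond the scatter stays open.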